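The source may report more compounds than this note shows. Statements on the series, on what has been measured and on what is new or still open speak of the compounds shown alone.

Values in an ADME assay on S9 fraction from liver (Homo sapiens) for metabolic stability, with a stated time of 1 h; on this read-out lower numbers stand for a less stable compound and higher numbers for a more stable compound:
compound 1 `N#Cc1cnc(NCc2cnccc2C(F)(F)F)cc1N[C@H]1C[C@H](O)C1`: 96%
compound 2 `N#Cc1cnc(NCc2cnccc2C(F)(F)F)cc1NC[C@H]1C[C@@H](O)C1`: 84%
compound 3 `N#Cc1cnc(NCc2cnccc2C(F)(F)F)cc1NC[C@H]1C[C@H](O)C1`: 93%
compound 4 `CO[C@H]1CC[C@@H](Nc2cc(NCc3cnccc3C(F)(F)F)ncc2C#N)CC1`: not yet measured

Compound 1 stands clear of one compound only: the data show a number 12 percentage points lower from compound 1 to compound 2 (beyond the scatter), against a number 3 percentage points lower from compound 1 to compound 3 (within the scatter). Compound 4 carries 4-methoxycyclohexyl in place of 3-hydroxycyclobutyl on a nitrogen on an aromatic ring. The measured changes at this nitrogen are those two steps, and the mirror-image pair adds a number 9 percentage points higher from compound 2 to compound 3 (within the scatter). None of them covers a six-membered ring or a methoxy group, so they guide the size only loosely. With a number 12 percentage points lower from compound 1 to compound 2 (beyond the scatter) as the largest step at this place, a modest fall is expected, and the estimated step is a number 14 percentage points lower from compound 1 to compound 4 (beyond the scatter). For compound 4 the expected value is 82%, with an estimated range of 62% to 97%.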

Compound 4, percent of the compound remaining: 19%
Beside the measured number, compound 4's estimate is 63 percentage points above it; measured number outside the range, below it.
By their numbers in this assay, from the lowest: compound 4; then compounds 2, 3 and 1 (each within the scatter of the next, the first and the last beyond it).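

In this assay, the group on this nitrogen on an aromatic ring can move the number far more than the earlier changes suggested: a number 77 percentage points lower from compound 1 to compound 4 (beyond the scatter), a number 74 percentage points lower from compound 3 to compound 4 (beyond the scatter) and a number 65 percentage points lower from compound 2 to compound 4 (beyond the scatter). The position therefore does not accept every saturated ring, and 4-methoxycyclohexyl, with its six-membered ring and no hydrogen-bond donor, stands well apart from the three hydroxylated groups. Nothing at hand bears on the cause of this fall.

Ring size and the methoxy group change together in these steps and cannot be separated. A 4-hydroxycyclohexyl or 3-methoxycyclobutyl group would address each on its own.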